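Fluoro Scan on Two Triazole Cores

A few compounds are considered here, and "the series" means these few. Any claim that something is new, unique, unknown or untested is made for them only; others in the source may bear on it.

The series compares two cores carrying a methylsulfonyl group and a phenyl group. Compound 2 is `Cn1c(-c2ccccc2)nnc1S(C)(=O)=O` and compound 1 is `Cn1c(-c2cccc(F)c2)nnc1S(C)(=O)=O`; they differ by fluoro in place of hydrogen on an aromatic carbon. Compound 3 is `Cn1nc(-c2ccccc2)nc1S(C)(=O)=O`; the difference between the core of compound 2 and that of compound 3 is not broken down here. Compound 4, `Cn1nc(-c2cccc(F)c2)nc1S(C)(=O)=O`, is not yet measured and differs from compound 3 by fluoro in place of hydrogen on an aromatic carbon, the same change as from compound 2 to compound 1.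

In a functional assay on the whole organism for antagonist activity, with Mus musculus as the target (a higher number here means that more compound is needed for the effect, a lower number that less compound is needed), compound 2 gives a limit of the assay, > 200 mg/kg. In this assay compound 1 likewise gives only a limit, > 200 mg/kg. For compound 3 in this assay the result is again a limit, > 200 mg/kg. This leaves a step that the two limits leave unreadable from compound 2 to compound 1.

Resting on (the limit of > 200 mg/kg in this assay, at which 3 of the 3 values shown sit), a step that the limit leaves unreadable from compound 3 to compound 4 in this assay is expected. Compound 4 is expected to give 300 mg/kg.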

Compound 4, dose for half-maximal effect: > 100 mg/kg
Compound 4: no number, only a limit; the forecaster's own chance of this, stated with the estimate: 85%; the middle value does not contradict the limit.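

Only limits stand for compound 3 and compound 4 in this assay, and the step between them cannot be read. The compounds shown leave open what dose, if any, gives a half-maximal effect on either core.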